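Compound 2 and the step to compound 4

The source may report more compounds than this note shows. Statements on the series, on what has been measured and on what is new or still open speak of the compounds shown alone.

Measured in a functional assay on A2780 cells (Homo sapiens) for inhibition, read by sulforhodamine B assay, with a stated time of 72 h; a lower number here means a stronger inhibitor, a higher number a weaker inhibitor:
Compound 1 `Cn1c(C(=O)NCc2ccc(S(=O)(=O)c3ccccc3)cc2)cc2ccncc21`: > 10000 nM (a limit)
Compound 2 `O=C(NCc1ccc(S(=O)(=O)N2CCCCC2)cc1)c1cc2ccncc2[nH]1`: 1700 nM
Compound 3 `O=C(NCc1ccc(S(=O)(=O)c2ccccc2)cc1)c1cn2ccnc2cn1`: > 10000 nM (a limit)

Among the measured compounds shown here, compound 2 holds the only actual number among the three, since the other results stand at the limit of > 10000 nM in this assay, at which 2 of the 3 values shown sit. Compound 4 `O=C(NCc1ccc(S(=O)(=O)N2CCCCC2)cc1)c1cc2cccnc2s1` is still to be measured in this assay. It differs from compound 2 at one place: a group of 9 heavy atoms (7 carbon, 1 nitrogen, 1 sulfur; one five-membered aromatic ring with 1 hetero atom, one six-membered aromatic ring with 1 hetero atom) in place of a group of 9 heavy atoms (7 carbon, 2 nitrogen; one five-membered aromatic ring with 1 hetero atom, one six-membered aromatic ring with 1 hetero atom), on a carbonyl carbon. For the measured compounds named here, no measured pair shows this change, so its size remains a matter of judgment. Going by the values given here, with compound 2 at 1700 nM as the sole numeric reading, a move toward weaker inhibition, beyond the usual scatter, is expected. The expected step is a 3.5-fold higher number from compound 2 to compound 4 (0.55 log units; beyond the scatter). For compound 4 the estimated value is 6000 nM, with an expected range of 1800 nM to 15000 nM.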

Compound 4, half-maximal inhibitory concentration: > 10000 nM
Compound 4: no number, only a limit; the forecaster's own chance of this, stated with the estimate: 45%; middle value at least 1.6-fold (0.22 log units) away from the limit.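

In this assay, among the compounds shown here, this exchange on the carbonyl carbon gives the first readable step at this place: an at least 5.8-fold higher number from compound 2 to compound 4 (0.76 log units; beyond the scatter). Compound 4 is a limit and not a number, and it joins the other compounds at that limit: the limit of > 10000 nM in this assay, at which 3 of the 4 values shown sit. The group that leaves has 1 hydrogen-bond donor and the group that enters has 0, but this single pair cannot tie the step to that count.

On these data alone, how far compound 4 lies past the limit stays open. So does whether an amine or a carboxylic acid on this carbonyl carbon would give a measurable number.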